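Nitro for fluoro on the aryl ring: expected inhibition of compound 4

The source may report more compounds than this note shows. Statements on the series, on what has been measured and on what is new or still open speak of the compounds shown alone.

Compound 1 `Cc1ccc(-c2ccc(F)cc2)n1-c1ccc(-c2nc3ccccc3s2)cc1` gives 11800 nM in a functional assay on MDA-MB-231 cells (Homo sapiens) for cytotoxicity, read by MTT assay, with a stated time of 72 h; on this read-out higher numbers stand for weaker inhibition and lower numbers for stronger inhibition.
Compound 2 `Cc1ccc(-c2ccc([N+](=O)[O-])cc2)n1-c1ccc(-c2nc3ccccc3s2)cc1` gives 12100 nM in this assay.
Compound 3 `Cc1ccc(-c2ccc(F)cc2)n1-c1ccc(-c2nc3ccc(F)cc3s2)cc1` gives 14100 nM in this assay.

Among these three, compound 3 carries the highest number, yet its gap to compound 2 and to compound 1 both sit within the usual scatter, so no real ordering among them can be claimed. Compound 4 `Cc1ccc(-c2ccc([N+](=O)[O-])cc2)n1-c1ccc(-c2nc3ccc(F)cc3s2)cc1` is the not yet measured partner of compound 3; the change is nitro in place of fluoro on an aromatic carbon. The same swap has already been seen once, on the core without the extra fluorine: a 1.0-fold higher number from compound 1 to compound 2 (0.01 log units; within the scatter). The other step, a 1.2-fold higher number from compound 1 to compound 3 (0.08 log units; within the scatter), shows that adding fluorine to the shared core also left the number essentially unchanged. Among the compounds with values here, with the only matching precedent flat, compound 4 is expected to sit close to compound 3, with a 1.0-fold lower number from compound 3 to compound 4 (0.00 log units; within the scatter) as the estimated step, that is, no movement beyond the scatter. Compound 4 is therefore estimated at 14000 nM, within a range from 7000 nM to 28000 nM.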

Compound 4, half-maximal inhibitory concentration: 17000 nM
Compound 4: the middle estimate sits 1.2-fold (0.08 log units) below what was measured; the measured number falls inside the stated range.
By their numbers in this assay, from the lowest: compounds 1, 2, 3 and 4 (each within the scatter of the next).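

In this assay, the change from 4-fluorophenyl to 4-nitrophenyl can now be read on a second core, where a 1.2-fold higher number from compound 3 to compound 4 (0.08 log units; within the scatter) shows it again stays small, so the flat result no longer rests on one pair: the same change on two cores in this assay, a 1.0-fold higher number (0.01 log units; within the scatter) from compound 1 to compound 2 and a 1.2-fold higher number (0.08 log units; within the scatter) from compound 3 to compound 4, 1.2-fold (0.07 log units) apart, within the scatter of two such steps The fluorine added to the shared core can also be read a second time, now with the nitro group in place, and a 1.4-fold higher number from compound 2 to compound 4 (0.15 log units; within the scatter) agrees with the earlier step: the same change on two cores in this assay, a 1.2-fold higher number (0.08 log units; within the scatter) from compound 1 to compound 3 and a 1.4-fold higher number (0.15 log units; within the scatter) from compound 2 to compound 4, 1.2-fold (0.07 log units) apart, within the scatter of two such steps Neither change therefore moves the number beyond the scatter on either core.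

The compounds shown carry only fluoro and nitro at this position, so they leave open whether an amine or a carboxylic acid there would move the number beyond the scatter. They also say nothing about how these compounds behave in other cell types.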